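The source may hold more compounds than are shown below. What is called first, only, known or untested is meant among the compounds shown, and "the series" means these compounds.

In a functional assay on MOLT-4 cells (Homo sapiens) for inhibition, read by MTT assay, with a stated time of 48 h (on this read-out higher numbers stand for weaker inhibition and lower numbers for stronger inhibition), compound 1 `CCOC(=O)C(=O)CC(=O)/C=C/c1cc(C(=O)c2ccccc2F)c[nH]1` gives 15000 nM and compound 3 `O=C(/C=C/c1cc(C(=O)c2ccccc2F)c[nH]1)CC(=O)C(=O)O` gives 20000 nM. For the measured compounds named here, these are the only two numbers available, and they lie within the scatter of each other. The remaining measured relative, compound 2 `CCOC(=O)C(=O)CC(=O)/C=C/c1cc(C(=O)c2ccccc2)cn1Cc1ccccc1`, offers no help, as its entry reads "not determined" (no result reported).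

Compound 4 `O=C(/C=C/c1cc(C(=O)c2cccc(F)c2)c[nH]1)CC(=O)C(=O)O` has the same atoms as compound 3, joined differently: 3-fluorophenyl stands in place of 2-fluorophenyl on a carbonyl carbon (3-fluorophenyl in place of 2-fluorophenyl on a carbonyl carbon).

Going by the values given here, the only measured step, a 1.3-fold higher number from compound 1 to compound 3 (0.12 log units; within the scatter), swaps ethyl for hydrogen elsewhere in the molecule and leaves the fluorophenyl group untouched. Among the compounds with values here, no measured pair moves the fluorine, so the data give no direct guide to this change, and the one step available gives no reason to expect a large shift.

The estimated step, with no direction favoured and no change expected beyond the scatter, is a 1.1-fold lower number from compound 3 to compound 4 (0.05 log units; within the scatter). In this assay, the expected value for compound 4 is 18000 nM, within an estimated range of 7000 nM to 45000 nM.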

Compound 4, half-maximal inhibitory concentration: > 40000 nM
Compound 4 ended at the assay's limit; the forecaster's own chance of this, stated with the estimate: 10%; at least 2.2-fold (0.34 log units) between middle value and limit.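

In this assay compound 4 gives no exact number, only a limit of the assay: > 40000 nM. Moving the fluorine within the ring gives an at least 2.0-fold higher number from compound 3 to compound 4 (0.30 log units; that floor lies within the scatter), the first measured step at this position on the carbonyl carbon, since the earlier step changed only the ethyl group at the other end of the molecule. That step is a floor, and the floor itself lies within the scatter, so it hints that 3-fluorophenyl may be worse than 2-fluorophenyl here without establishing a real loss: the limit of > 40000 nM in this assay, at which 1 of the 4 values shown sits.

From the compounds shown here alone, how far the true value of compound 4 lies past its limit remains unknown, so the real size of this step stays open. Going by these compounds, how a chlorophenyl or a methoxyphenyl group on the same carbonyl carbon would compare also remains open.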